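Relocating the Acid and Fluorine on the Distal Ring

The source may hold more compounds than are shown below. What is called first, only, known or untested is meant among the compounds shown, and "the series" means these compounds.

Compound 1 `Cc1c(OCCCCOc2ccc(F)c(C(=O)O)c2)ccc(C(=O)CC2CCCC2)c1O` gives 699 nM in an assay on HEK293 cells for positive allosteric modulation of metabotropic glutamate receptor 2 (Rattus norvegicus), read by thallium flux, with a stated time of 2.5 min (a lower number here means that less compound is needed, a higher number that more compound is needed for the effect), and stands highest of the three numbers measured. Compound 2 `CCCC(=O)c1ccc(OCCCCOc2ccc(F)c(C(=O)O)c2)c(C)c1O` gives 74 nM in this assay, and compound 3 `Cc1c(OCCCCOc2ccc(F)c(C(=O)O)c2)ccc(C(=O)CC(C)(C)C)c1O` gives 208 nM. The two steps away from compound 1 are a 9.4-fold lower number from compound 1 to compound 2 (0.98 log units; beyond the scatter) and a 3.4-fold lower number from compound 1 to compound 3 (0.53 log units; beyond the scatter), while a 2.8-fold higher number from compound 2 to compound 3 (0.45 log units; beyond the scatter) separates the other two; all three steps alter only the group on the saturated chain carbon bound to the carbonyl carbon.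

Compound 4 `Cc1c(OCCCCOc2ccc(C(=O)O)cc2F)ccc(C(=O)CC2CCCC2)c1O` is a rearrangement of compound 1 rather than a trimming or growth: 4-carboxy-2-fluorophenyl in place of 3-carboxy-4-fluorophenyl on an oxygen on a saturated carbon. The carboxylic acid and the fluorine stay on the ring but change places with respect to the oxygen on the saturated carbon.

For the measured compounds named here, none of the measured steps touches this end of the molecule, so none bears directly on the change, and the data give no steer in either direction. Absent such evidence, the step of a 1.3-fold higher number from compound 1 to compound 4 (0.11 log units; within the scatter) is expected to be small, though the uncertainty is wide. Compound 4 is therefore estimated at 900 nM in this assay, with a range from 200 nM to 4000 nM.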

Compound 4, half-maximal effective concentration: 639 nM
Compound 4: the middle estimate sits 1.4-fold (0.15 log units) above what was measured, and the stated range covers the measured number.
By their numbers in this assay, from the lowest: compound 2; then compound 3; then compounds 4 and 1 (each within the scatter of the next).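

In this assay the exchange of 3-carboxy-4-fluorophenyl for 4-carboxy-2-fluorophenyl on an oxygen on a saturated carbon comes with a 1.1-fold lower number from compound 1 to compound 4 (0.04 log units; within the scatter) and so leaves the two compounds indistinguishable in this measurement. For the compounds shown here, the earlier compounds varied only the group on the saturated chain carbon bound to the carbonyl carbon, where every step lay beyond the scatter, whereas this pair gives the first reading at the other end of the molecule and shows that, with the cyclopentyl group in place, the acid and the fluorine can change places on this ring without a change beyond the scatter. No available evidence bears on what lies behind this outcome.

The compounds shown leave open whether the same exchange would be equally silent with the ethyl group of compound 2, which gives 74 nM and so offers a lower starting number against which a change could be read. They also leave open how this end of the molecule would respond to a tetrazole in place of the carboxylic acid, or to a chlorine in place of the fluorine.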